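Adding a Third Methoxy Group to Compound 2

A few compounds are considered here, and "the series" means these few. Any claim that something is new, unique, unknown or untested is made for them only; others in the source may bear on it.

Of the compounds shown here, two sharing the same core have been tested in a functional assay on MDA-MB-231 cells (Homo sapiens) for antiproliferative activity, read by MTT assay, with a stated time of 24 h; on this read-out higher numbers stand for weaker inhibition and lower numbers for stronger inhibition. Compound 1 `COc1cc(C(=O)/C=C/c2cc(-c3cc(OC)c(OC)c(OC)c3)n3nc(-c4ccccc4)cc3n2)cc(OC)c1OC` gives 24300 nM in this assay, and compound 2 `COc1ccc(/C=C/C(=O)c2cc(-c3cc(OC)c(OC)c(OC)c3)n3nc(-c4ccccc4)cc3n2)cc1OC` gives 14200 nM. These two numbers do not differ beyond the scatter of the method, so compound 2 and compound 1 cannot be told apart on this evidence; both inhibit cell growth only at high concentrations.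

Compound 3 `COc1cc(/C=C/C(=O)c2cc(-c3cc(OC)c(OC)c(OC)c3)n3nc(-c4ccccc4)cc3n2)cc(OC)c1OC` has not yet been measured. It differs from compound 2 in one place: methoxy in place of hydrogen on an aromatic carbon. Put another way, the 3,4-dimethoxyphenyl group of compound 2 becomes a 3,4,5-trimethoxyphenyl group in compound 3.

For the measured compounds named here, no pair of measured compounds differing in exactly one place is available, so nothing indicates how far this single change moves the number in this assay. A step of modest size is expected, as a 1.2-fold lower number from compound 2 to compound 3 (0.07 log units; within the scatter), most likely staying within the scatter and without a clear direction. For compound 3 in this assay, the estimated value is 12000 nM, with a range from 4500 nM to 32000 nM.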

Compound 3, half-maximal inhibitory concentration: 18400 nM
The estimate for compound 3 lay 1.5-fold (0.19 log units) below the measured number, and the stated range covers the measured number.
By their numbers in this assay, from the lowest: compounds 2, 3 and 1 (each within the scatter of the next).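

Turning the 3,4-dimethoxyphenyl group of compound 2 into the 3,4,5-trimethoxyphenyl group of compound 3 gives the first single-place comparison in this series: in this assay there is a 1.3-fold higher number from compound 2 to compound 3 (0.11 log units; within the scatter) and so no measurable effect of the change. At this aromatic carbon, ortho to a methoxy group, hydrogen and methoxy therefore cannot be told apart on this read-out, and the two added heavy atoms neither clearly help nor clearly harm growth inhibition. No measurement is available that could explain this outcome.

A hydroxy group, a fluorine atom, an amine or a longer chain such as butoxy at this same carbon remains an open case, as does whether any group here could move the number beyond the scatter. This single pair also leaves open whether the same swap would behave alike on a different core or when the other aromatic groups of the molecule carry different substituents.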